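Inverting One Stereocentre of the Most Potent Compound

The source may hold more compounds than are shown below. What is called first, only, known or untested is meant among the compounds shown, and "the series" means these compounds.

In a functional assay on HCC827 cells (Homo sapiens) for antiproliferative activity, read by MTT assay, with a stated time of 72 h (on this read-out lower numbers stand for stronger inhibition and higher numbers for weaker inhibition), compound 1 `CN1CCN(c2ccc(Nc3ncc4nc(Nc5ccccc5)n([C@H]5CCN(C(=O)OC(C)(C)C)C5)c4n3)cc2)CC1` gives 110 nM and compound 2 `CN1CCN(c2ccc(Nc3ncc4nc(Nc5ccccc5)n([C@@H]5CCNC5)c4n3)cc2)CC1` gives 65 nM. Compound 3 `CN1CCN(c2ccc(Nc3ncc4nc(Nc5ccccc5)n([C@@H]5CCN(S(=O)(=O)C6CC6)C5)c4n3)cc2)CC1` gives 0.88 nM, the lowest number of the three and so the strongest inhibition measured. Compound 4 `CN1CCN(c2ccc(Nc3ncc4nc(Nc5ccccc5)n([C@H]5CCN(S(=O)(=O)C6CC6)C5)c4n3)cc2)CC1` is its stereoisomer: the two compounds have the same atoms and bonds and differ only in configuration as drawn: 1 of 1 stereo elements differ; a stereocentre at a saturated ring carbon is drawn R in compound 3 and S in compound 4. The same atoms and bonds remain, and a stereocentre at a saturated ring carbon is drawn R in compound 3 and S in compound 4.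

The measured steps all change a group rather than configuration alone. One is a 1.7-fold lower number from compound 1 to compound 2 (0.23 log units; within the scatter), a second is a 130-fold lower number from compound 1 to compound 3 (2.10 log units; beyond the scatter), and a third is a 74-fold lower number from compound 2 to compound 3 (1.87 log units; beyond the scatter). Within the data shown here, no measured pair isolates the effect of configuration, so its size remains uncertain. The large step to compound 3, a 74-fold lower number from compound 2 to compound 3 (1.87 log units; beyond the scatter), shows how far numbers can move in this small set, yet it leaves compound 3 at the extreme, so a rise seems likelier than a further fall. The expected step is a 5.7-fold higher number from compound 3 to compound 4 (0.75 log units; beyond the scatter), towards weaker inhibition, with a wide margin. In this assay, compound 4 is estimated at 5 nM, with an expected range of 0.8 nM to 40 nM.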

Compound 4, half-maximal inhibitory concentration: 1.6 nM
For compound 4 the middle estimate is 3.1-fold (0.49 log units) above the measured one, and the stated range covers the measured number.
By their numbers in this assay, from the lowest: compounds 3 and 4 (each within the scatter of the next); then compounds 2 and 1 (each within the scatter of the next).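

In this assay, among these compounds, a 1.8-fold higher number from compound 3 to compound 4 (0.26 log units; within the scatter) is the first step here that changes configuration alone, and at this saturated ring carbon the change from R to S stays within the usual scatter: the fact that compounds 3 and 4 differ only in the configuration as drawn.

The large gain with the cyclopropylsulfonyl group is therefore not tied to one drawn configuration, as it also appears in the S form, with a 41-fold lower number from compound 2 to compound 4 (1.61 log units; beyond the scatter) and a 69-fold lower number from compound 1 to compound 4 (1.84 log units; beyond the scatter). In this set, the large moves follow the group on the ring nitrogen, while inverting the stereocentre leaves the number within the scatter.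

On these data alone, compound 1 and compound 2 each appear in only one configuration, so it remains open whether inversion would matter as little with tert-butoxycarbonyl or with the free amine. Also open, as far as these compounds go, is how a methylsulfonyl or an acetyl group on that ring nitrogen would compare.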